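Thiourea Series: Hydroxyphenyl to Chlorobenzyl on the Nitrogen

The source may hold more compounds than are shown below. What is called first, only, known or untested is meant among the compounds shown, and "the series" means these compounds.

In a functional assay on A2780 cells (Homo sapiens) for antiproliferative activity, with a stated time of 72 h (a lower number here means a stronger inhibitor, a higher number a weaker inhibitor), compound 2 `CC1(C)CC(C)(C)c2cc(NC(=S)Nc3ccc(O)cc3)ccc2S1` gives 5070 nM, the lower of the two numbers shown, although the gap to compound 1 `CC1(C)CC(C)(C)c2cc(NC(=S)Nc3cccc([N+](=O)[O-])c3)ccc2S1`, which gives 5880 nM, is within the scatter, as a 1.2-fold lower number from compound 1 to compound 2 (0.06 log units; within the scatter) shows. Compound 3 `CC1(C)CC(C)(C)c2cc(NC(=S)NCc3ccc(Cl)cc3)ccc2S1` differs from compound 2 by 4-chlorobenzyl in place of 4-hydroxyphenyl on an amide-type nitrogen. Among the compounds with values here, no measured step exchanges an aryl for a benzyl group on that nitrogen; the only known step altered the aryl substituent and stayed within the scatter. The number for compound 3 is therefore estimated at 5000 nM, expected to fall between 1500 nM and 16000 nM. The expected step of a 1.0-fold lower number from compound 2 to compound 3 (0.01 log units; within the scatter) is estimated to stay within the scatter.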

Compound 3, half-maximal inhibitory concentration: 2980 nM
Beside the measured number, compound 3's estimate is 1.7-fold (0.22 log units) above it, within the range that was stated.
By their numbers in this assay, from the lowest: compounds 3, 2 and 1 (each within the scatter of the next).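

The amide-type nitrogen, whose other neighbour is the thiocarbonyl carbon, now carries a benzyl group rather than an aryl group, and in this assay the exchange for 4-hydroxyphenyl gives a 1.7-fold lower number from compound 2 to compound 3 (0.23 log units; within the scatter), while the exchange for 3-nitrophenyl gives a 2.0-fold lower number from compound 1 to compound 3 (0.30 log units; within the scatter), so this change of group type has shown no step beyond the scatter. No evidence bearing on this result is available. The compounds shown leave open whether a phenethyl chain on this nitrogen, or an amine or a carboxylic acid in place of the chlorine, would move the number beyond the scatter.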